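Camphor-derived triazole amides: aryl substituent shift in SGC-7901 assay

A few compounds are considered here, and "the series" means these few. Any claim that something is new, unique, unknown or untested is made for them only; others in the source may bear on it.

Measured so far:
- compound 1, `CC1(C)[C@H]2CC[C@]1(C)N(Cc1cn(-c3cccc(Cl)c3)nn1)C(=O)C2`: 510 nM
- compound 2, `COc1ccccc1-n1cc(CN2C(=O)C[C@@H]3CC[C@@]2(C)C3(C)C)nn1`: 280 nM

Both compounds were read in a functional assay on SGC-7901 cells (Homo sapiens) for inhibition, read by MTT assay, with a stated time of 24 h; a higher number here means a weaker inhibitor, a lower number a stronger inhibitor. Compound 1 gives 510 nM and compound 2 gives 280 nM; the two differ only in the aryl group on the aromatic nitrogen, and the step of a 1.8-fold lower number from compound 1 to compound 2 (0.26 log units; within the scatter) lies within the scatter, so compound 2 has the lower of the two numbers but no real order between them can be claimed.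

Compound 3, `COc1ccc(-n2cc(CN3C(=O)C[C@@H]4CC[C@@]3(C)C4(C)C)nn2)cc1`, is not yet measured. Its change from compound 2 is 4-methoxyphenyl in place of 2-methoxyphenyl on an aromatic nitrogen. Going by the values given here, only the step from compound 1 to compound 2 bears on a change of the aryl group here, and it was within the scatter. Among the compounds with values here, no measured pair shows what moving the methoxy substituent around the ring does. The expectation for compound 3 in this assay is therefore a step of a 1.3-fold higher number from compound 2 to compound 3 (0.10 log units; within the scatter), that is, nothing beyond the scatter in either direction. Compound 3 is estimated at 350 nM, with a range from 150 nM to 900 nM.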

Compound 3, half-maximal inhibitory concentration: 480 nM
Beside the measured number, compound 3's estimate is 1.4-fold (0.14 log units) below it; low and high end bracket the measured number.
By their numbers in this assay, from the lowest: compounds 2, 3 and 1 (each within the scatter of the next).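

Going by these compounds alone, compound 3 gives the first pair in which one substituent is relocated on the aryl ring while everything else stays the same. In this assay, 4-methoxyphenyl in place of 2-methoxyphenyl on the aromatic nitrogen gives a 1.7-fold higher number from compound 2 to compound 3 (0.23 log units; within the scatter) and so shows no readable effect of methoxy placement in this pair. The exchange of 3-chlorophenyl for 4-methoxyphenyl at this position gives a 1.1-fold lower number from compound 1 to compound 3 (0.03 log units; within the scatter) and also stays within the scatter, so all three aryl groups now sit within the scatter of one another, and no order among compounds 1, 2 and 3 can be stated. No separate measurement is available to bear on these results.

As far as these compounds go, it remains open whether an unsubstituted phenyl, or an aryl group carrying an amine or a carboxylic acid, would produce a step beyond the scatter at this aromatic nitrogen. Also open, from the compounds shown here alone, is whether a longer chain in place of the link between the shared core and the five-membered aromatic ring would leave the numbers this close together.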